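Single-substituent swap on the pendant aryl ring

The source may hold more compounds than are shown below. What is called first, only, known or untested is meant among the compounds shown, and "the series" means these compounds.

Measured compounds:
compound 1 `COc1ccc(S(=O)(=O)N2CCc3cccc(-c4ccc(C#N)cc4)c32)cc1`: 29.5 nM
compound 2 `COc1ccc(S(=O)(=O)N2CCc3cccc(-c4cc(OC)c(OC)c(OC)c4)c32)cc1`: 6340 nM

Both were run in a functional assay on NCI-H460 cells (Homo sapiens) for inhibition, with a stated time of 72 h; a higher number here means a weaker inhibitor, a lower number a stronger inhibitor. Compound 1 gives 29.5 nM and holds the lower of the two numbers; compound 2 gives 6340 nM, a gap well beyond the scatter. Among the measured compounds shown here, compound 2 differs from compound 1 in more than one place, so no single-change step can be drawn from the pair.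

Compound 3 `COc1ccc(-c2cccc3c2N(S(=O)(=O)c2ccc(OC)cc2)CC3)cc1` is unmeasured. Against compound 1 the change is methoxy in place of cyano on an aromatic carbon. Read one bond further out it is 4-cyanophenyl to 4-methoxyphenyl, with the shared core otherwise untouched.

For the measured compounds named here, no measured step isolates this change. Compound 2, which carries methoxy on the same aryl ring, is much weaker, but several other changes accompany it there. The step from compound 1 to compound 3 is expected to be a moderate loss, a 6.8-fold higher number from compound 1 to compound 3 (0.83 log units; beyond the scatter). Compound 3 is accordingly estimated at 200 nM, within 30 nM to 2000 nM.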

Compound 3, half-maximal inhibitory concentration: 302 nM
The estimate for compound 3 lay 1.5-fold (0.18 log units) below the measured number; low and high end bracket the measured number.
By their numbers in this assay, from the lowest: compound 1; then compound 3; then compound 2.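

In this assay, among the compounds shown here, compound 3 gives the first single-change reading at this position: methoxy in place of cyano, on an aromatic carbon para to a large group, yields a 10-fold higher number from compound 1 to compound 3 (1.01 log units; beyond the scatter). The position therefore responds strongly to the identity of its substituent, even though the leaving and entering groups match in heavy-atom count and hydrogen-bond acceptor count. No available measurement bears on the origin of this step.

For the compounds shown here, with only two groups compared directly at this position, it remains open whether the step reflects the loss of cyano or the arrival of methoxy. Fluorine, an amine or a carboxylic acid at the same carbon could help separate these readings, and the effect of moving either group elsewhere on the pendant ring also remains unresolved.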